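A Remote Substituent Swap and an Unchanged Acid Dissociation

A few compounds are considered here, and "the series" means these few. Any claim that something is new, unique, unknown or untested is made for them only; others in the source may bear on it.

Of the compounds shown here, three sharing one core have been measured in a physicochemical assay for acid dissociation. Compound 1 `COc1cccc(CNCCCNc2ccnc3cc(Cc4ccccc4)ccc23)c1O` gives 9.47. Compound 2 `COc1cccc(CNCCCNc2ccnc3cc(-c4ccc(C(F)(F)F)cc4)ccc23)c1O` gives 9.47, and compound 3 `COc1cccc(CNCCCNc2ccnc3cc(CCC(C)C)ccc23)c1O` gives 9.47. The steps between them are no change at the digits printed from compound 1 to compound 2 (within the scatter), no change at the digits printed from compound 1 to compound 3 (within the scatter) and no change at the digits printed from compound 2 to compound 3 (within the scatter). Compound 3 therefore stands level with compounds 1 and 2 at the digits shown: the exchanges at this aromatic carbon, between a benzyl, a 4-(trifluoromethyl)phenyl and an isopentyl group, left the proton equally willing to leave in every case.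

Compound 4 `COc1cccc(Oc2ccc3c(NCCCNCc4cccc(OC)c4O)ccnc3c2)c1` is the next member of the set and has not yet been measured. Its difference from compound 3 is 3-methoxyphenoxy in place of isopentyl on an aromatic carbon. This change sits at the same aromatic carbon as the three earlier exchanges, and each of those earlier exchanges stayed within the scatter of the measurement, so a further exchange there is expected to give no step beyond the scatter, no change at the digits printed from compound 3 to compound 4 (within the scatter). Compound 4 is accordingly estimated at 9.47, with an expected range from 9.2 to 9.75 in this assay.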

Compound 4, acid dissociation constant: 9.28
Estimate against measurement, compound 4: 0.19 log units above; the range from low to high includes it.
By their numbers in this assay, from the lowest: compounds 4, 1, 2 and 3 (each within the scatter of the next).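

In this assay, putting 3-methoxyphenoxy on this aromatic carbon gives a number 0.19 log units lower from compound 3 to compound 4 (within the scatter) and a number 0.19 log units lower from compound 2 to compound 4 (within the scatter) and also a number 0.19 log units lower from compound 1 to compound 4 (within the scatter) as the comparison with the remaining earlier compound. Going by these compounds alone, the earlier exchanges involved only groups without oxygen, so this is the first evidence from a larger group of 9 heavy atoms, with an oxygen joining its ring to the core and 2 hydrogen-bond acceptors, and even this change stays inside the normal spread of repeated measurements, so all four compounds remain indistinguishable and none goes against that reading. Nothing available here offers any independent information on what governs higher or lower read-outs in these compounds, so the result can only be recorded as an observation.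

As far as these compounds go, whether a group of a different kind, such as an amine or a carboxylic acid, would leave the number at this aromatic carbon just as undisturbed remains open. Also open, from the compounds shown here alone, is how far the same holds for changes away from this carbon, for example a longer chain in place of the one linking the two aromatic parts of the shared core.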